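The source may report more compounds than this note shows. Statements on the series, on what has been measured and on what is new or still open speak of the compounds shown alone.

Compound 1 `CC(C)(C)CC#Cc1cc2ncnc(Nc3ccc(OCc4cccc(F)c4)c(Cl)c3)c2s1`: 29.3 uM
Compound 2 `CCCN(CC#Cc1cc2ncnc(Nc3ccc(OCc4cccc(F)c4)c(Cl)c3)c2s1)CCC`: 26.5 uM

In an ADME assay on HepG2 cells (Homo sapiens) for cytotoxicity (on this read-out higher numbers stand for lower toxicity in this test and lower numbers for higher toxicity in this test), compound 1 gives 29.3 uM, which lies within the scatter of compound 2. Compound 3 `COCC#Cc1cc2ncnc(Nc3ccc(OCc4cccc(F)c4)c(Cl)c3)c2s1` is not yet measured. It differs from compound 1 in one group: methoxy in place of tert-butyl on a saturated chain carbon bound to a triple-bonded carbon. For the measured compounds named here, the only measured step at this place, a 1.1-fold lower number from compound 1 to compound 2 (0.04 log units; within the scatter), brought in dipropylamino and stayed within the scatter. Going by the values given here, no measured compound carries methoxy, so this is thin evidence, and no change beyond the scatter is expected. The estimated step is a 1.1-fold lower number from compound 1 to compound 3 (0.04 log units; within the scatter). For compound 3 the expected value is 27 uM, with an estimated range of 13 uM to 55 uM.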

Compound 3, half-maximal toxic concentration: > 33 uM
Compound 3 gave a limit, no number (the forecaster's own chance of this, stated with the estimate: 10%); middle value at least 1.2-fold (0.08 log units) from the limit.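

In this assay compound 3 gives > 33 uM, which is a limit of the assay and not a number. Methoxy at this saturated chain carbon gives an at least 1.1-fold higher number from compound 1 to compound 3 (0.05 log units; that floor lies within the scatter), and against dipropylamino it gives an at least 1.2-fold higher number from compound 2 to compound 3 (0.09 log units; that floor lies within the scatter). So a third, oxygen-bearing group fits here without a lower number appearing, though these floors cannot show how large either step really is.

From the compounds shown here alone, whether any group on this carbon moves the number beyond the scatter remains open. A carboxylic acid or a hydroxyl group here could still give a different answer.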